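Chloro in Place of Hydroxy on Compound 1

The source may hold more compounds than are shown below. What is called first, only, known or untested is meant among the compounds shown, and "the series" means these compounds.

Compound 1 `Cn1cnc2c(N3CCCCC3)nc(-c3ccccc3O)nc21` stands at the top of the two numbers shown in an assay on cells for displacement of a labelled ligand from adenosine receptor A3 (Homo sapiens), read by scintillation counting and radioligand binding, with a stated time of 180 min, tested at 10 uM (a lower number here means less inhibition, a higher number more inhibition at the concentration tested (going by the name of the read-out)), where compound 1 gives 20%. Its nearest neighbour is compound 3 `CN1CCN(c2nc(-c3ccccc3O)nc3c2ncn3C)CC1`, which gives 15.3% in this assay; the step of a number 4.7 percentage points lower from compound 1 to compound 3 (within the scatter) lies within the scatter and exchanges 4-methylpiperazin-1-yl for piperidin-1-yl. Compound 2 `Clc1ccc(-c2nc(N3CCCCC3)c3nc[nH]c3n2)cc1` reaches > 80% in this assay, which is a limit rather than a number (the limit of > 80% in this assay, at which 1 of the 3 values shown sits). Compound 4 `Cn1cnc2c(N3CCCCC3)nc(-c3ccccc3Cl)nc21` differs from compound 1 by chloro in place of hydroxy on an aromatic carbon. Among the measured compounds shown here, no measured step covers this change; the only measured step concerns a different group, so no direction can be read from it. A modest upward step a number 15 percentage points higher from compound 1 to compound 4 (beyond the scatter) in this assay is expected, with wide uncertainty. Compound 4 is estimated at 35%, between 10% and 70%.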

Compound 4, a percentage reported as inhibition, at one concentration (the size of the read-out at that concentration, not a potency): 2.1%
For compound 4 the middle estimate is 32.9 percentage points above the measured one; measured number outside the range, below it.
By their numbers in this assay, from the lowest: compound 4; then compounds 3 and 1 (each within the scatter of the next). At a limit, above all of these: compound 2.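

In this assay, chloro in place of hydroxy on an aromatic carbon gives a number 17.9 percentage points lower from compound 1 to compound 4 (beyond the scatter). This shows that the place ortho to a large group on the six-membered aromatic ring responds to a single-atom exchange, whereas the earlier step, at the piperidin-1-yl group, stayed within the scatter. Nothing shown here gives a cause for this step.

The compounds shown do not separate the loss of hydroxy from the arrival of chloro. From the compounds shown here alone, a methoxy or an amino group at this place is not among them, so how other groups would fare there remains open.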